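Saturating the styryl linker of a quinazoline sulfamide

The source may hold more compounds than are shown below. What is called first, only, known or untested is meant among the compounds shown, and "the series" means these compounds.

Measured compounds:
Compound 1, `COc1cc2nc(/C=C/c3cccnc3)nc(N3CCC(CCNS(N)(=O)=O)CC3)c2cc1OC`: 58 nM
Compound 2, `COc1cc2nc(/C=C/c3ccncc3)nc(N3CCC(CCNS(N)(=O)=O)CC3)c2cc1OC`: 218 nM

Compound 1 gives 58 nM in an assay on cells for inhibition of Ectonucleotide pyrophosphatase/phosphodiesterase family member 1 (Homo sapiens), with a stated time of 60 min (a lower number here means a stronger inhibitor, a higher number a weaker inhibitor), the lower of the two numbers recorded. Within the data shown here, compound 2, which differs only in the pyridyl ring, gives 218 nM, and the step of a 3.8-fold higher number from compound 1 to compound 2 (0.58 log units; beyond the scatter) is the only measured comparison available.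

Compound 3, `COc1cc2nc(CCc3ccc(F)cc3)nc(N3CCC(CCNS(N)(=O)=O)CC3)c2cc1OC`, has not yet been measured. It differs from compound 1 in that (2-(4-fluorophenyl)ethyl in place of 2-(pyridin-3-yl)ethenyl on an aromatic carbon). This change removes the double bond outside aromatic rings and the single hydrogen-bond acceptor of the leaving group, and replaces the ring with one hetero atom by a ring of carbon only bearing fluorine. Among the measured compounds shown here, no measured pair shows exactly this kind of change; the step from compound 1 to compound 2 only shows that moving the nitrogen within the pyridyl ring already costs potency beyond the scatter. A change that removes the nitrogen and the double bond together is therefore expected to weaken binding by a comparable or somewhat larger amount, a 3.4-fold higher number from compound 1 to compound 3 (0.54 log units; beyond the scatter). Compound 3 is thus estimated at 200 nM, with a range of 60 nM to 700 nM.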

Compound 3, inhibition constant: 366 nM
Beside the measured number, compound 3's estimate is 1.8-fold (0.26 log units) below it; low and high end bracket the measured number.
By their numbers in this assay, from the lowest: compound 1; then compounds 2 and 3 (each within the scatter of the next).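

In this assay, putting 2-(4-fluorophenyl)ethyl in place of 2-(pyridin-3-yl)ethenyl on this aromatic carbon gives a 6.3-fold higher number from compound 1 to compound 3 (0.80 log units; beyond the scatter) and so costs potency beyond the scatter, yet inhibition remains measurable without either the double bond outside aromatic rings or a ring hetero atom. Set against the pyridin-4-yl compound, the same group gives a 1.7-fold higher number from compound 2 to compound 3 (0.23 log units; within the scatter) and the two cannot be told apart, so among these three compounds the advantage at this position belongs to the 2-(pyridin-3-yl)ethenyl group of compound 1 alone, not to pyridyl-bearing groups in general. No measurement at hand accounts for these differences.

Because compound 3 changes the linker and the ring at once, the share of the loss that belongs to each remains unresolved. A 2-(pyridin-3-yl)ethyl group, which keeps the ring and loses only the double bond, and a 2-(4-fluorophenyl)ethenyl group, which keeps the double bond and loses only the pyridine ring, would separate the two, and the compounds shown also leave open how a ring carrying an amine or a carboxylic acid would fare here.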